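The compounds below may be only part of what the source reports. "The series", "measured", "known", "first", "only" and "open" are said of these compounds alone.

Measured in an ADME assay on RAW264.7 cells (Mus musculus) for cytotoxicity, read by MTT assay, with a stated time of 48 h (a lower number here means that less compound is tolerated, a higher number that more compound is tolerated), so far:

compound 1 `CC(=O)OC[C@H]1O[C@H](OC[C@@H](Cn2cc(CN(c3nc(-c4ccc(Cl)cc4)no3)C3CCCCC3)nn2)OC(C)=O)C=C[C@@H]1OC(C)=O`: 35.5 ug/mL
compound 2 `CC(=O)OC[C@H]1O[C@H](OC[C@@H](Cn2cc(CN(c3nc(-c4ccccc4)no3)C3CCCCC3)nn2)OC(C)=O)C=C[C@@H]1OC(C)=O`: 28.6 ug/mL
compound 3 `CC(=O)OC[C@H]1O[C@H](OC[C@@H](Cn2cc(CN(c3nc(-c4ccc(C)cc4)no3)C3CCCCC3)nn2)OC(C)=O)C=C[C@@H]1OC(C)=O`: 45.3 ug/mL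

Compound 3 gives the highest of the three numbers, but its separation from the others is small: a 1.3-fold higher number from compound 1 to compound 3 (0.11 log units; within the scatter) and a 1.6-fold higher number from compound 2 to compound 3 (0.20 log units; within the scatter) are both within the scatter, so the three compounds are not distinguished in this assay.

Compound 4 `CC(=O)OC[C@H]1O[C@H](OC[C@@H](Cn2cc(CN(c3nc(-c4ccc(C(F)(F)F)cc4)no3)C3CCCCC3)nn2)OC(C)=O)C=C[C@@H]1OC(C)=O` is the next member. Relative to compound 3 the change is trifluoromethyl in place of methyl on an aromatic carbon.

All three measured steps concern the same aromatic carbon and therefore bear on this change: a 1.2-fold lower number from compound 1 to compound 2 (0.09 log units; within the scatter), a 1.3-fold higher number from compound 1 to compound 3 (0.11 log units; within the scatter) and a 1.6-fold higher number from compound 2 to compound 3 (0.20 log units; within the scatter). None of them leaves the scatter. Three different groups at this position have given the same outcome, so a step beyond the scatter is not expected when trifluoromethyl takes the place of methyl; the expected step is a 1.3-fold lower number from compound 3 to compound 4 (0.10 log units; within the scatter).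

Compound 4 is therefore estimated at 36 ug/mL in this assay, with a range from 22 ug/mL to 60 ug/mL.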

Compound 4, half-maximal cytotoxic concentration: 64.1 ug/mL
For compound 4 the middle estimate is 1.8-fold (0.25 log units) below the measured one; measured number above the stated range.
By their numbers in this assay, from the lowest: compounds 2, 1, 3 and 4 (each within the scatter of the next, the first and the last beyond it).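

In this assay, among these compounds, trifluoromethyl gives the first step at this aromatic carbon to leave the scatter, with a 2.2-fold higher number from compound 2 to compound 4 (0.35 log units; beyond the scatter), although that step is modest. The other two steps stay within the scatter, with a 1.4-fold higher number from compound 3 to compound 4 (0.15 log units; within the scatter) and a 1.8-fold higher number from compound 1 to compound 4 (0.26 log units; within the scatter), so the position separates only the hydrogen and trifluoromethyl compounds, and compound 4 remains undistinguished from compound 1 and compound 3. Nothing available accounts for the separation between compound 2 and compound 4.

Open, from the compounds shown here alone, is whether a carboxylic acid, an amine or a methoxy group on this aromatic carbon would leave the scatter relative to compound 3. Also open, going by these compounds, is whether the step from hydrogen to trifluoromethyl would recur with other changes made elsewhere on the shared core.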